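Methoxy for propyl on the acyl chain of compound 3

This account rests on a few compounds, and the source may have more. Where it says the series, first, only, none or still open, it means among the compounds named here.

Among the measured compounds shown here, in a functional assay on HCT-116 cells (Homo sapiens) for inhibition, read by MTT assay, with a stated time of 48 h (on this read-out higher numbers stand for weaker inhibition and lower numbers for stronger inhibition), compound 3 `CCCCC(=O)N(Cc1ccc(OC)c(O)c1)c1cc(OC)c(OC)c(OC)c1` gives 170 nM and holds the lower of the two actual numbers measured so far. Compound 1 `C/C=C/C(=O)N(Cc1ccc(OC)c([N+](=O)[O-])c1)c1cc(OC)c(OC)c(OC)c1` gives 670 nM in this assay, and its gap to compound 3 lies beyond the usual scatter. Compound 2 `COc1cc(NCc2ccccc2)cc(OC)c1OC` reads > 80000 nM, which is a limit of the assay and not a number.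

The next compound to be tested is compound 4 `COCC(=O)N(Cc1ccc(OC)c(O)c1)c1cc(OC)c(OC)c(OC)c1`. It differs from compound 3 in one place, with methoxy in place of propyl on a saturated chain carbon bound to a carbonyl carbon. Cut one bond further out, the same difference reads butyl to methoxymethyl.

For the measured compounds named here, no measured pair isolates this change, so its size has not been observed directly. The expectation therefore rests only on the structural change and on compound 3 at 170 nM as the starting point. A modest move toward a higher number, meaning weaker inhibition, is expected in this assay, with the estimated change being a 2.4-fold higher number from compound 3 to compound 4 (0.37 log units; beyond the scatter). The estimate for compound 4 is 400 nM, with an expected range of 120 nM to 1500 nM.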

Compound 4, half-maximal inhibitory concentration: 230 nM
The estimate for compound 4 lay 1.7-fold (0.24 log units) above the measured number; the measured number falls inside the stated range.
By their numbers in this assay, from the lowest: compounds 3 and 4 (each within the scatter of the next); then compound 1. At a limit, above all of these: compound 2.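

In this assay, among the compounds shown here, this is the first step that isolates one change, and methoxy in place of propyl on a saturated chain carbon bound to a carbonyl carbon gives a 1.4-fold higher number from compound 3 to compound 4 (0.13 log units; within the scatter), so the two compounds cannot be told apart on this read-out. At this position, therefore, the 3 carbon atoms of propyl can give way to the 1 carbon and 1 oxygen of methoxy, adding 1 hydrogen-bond acceptor, with no change that this assay can resolve; compounds 1 and 2 differ from compound 3 in more than one place and could not show this. Nothing shown bears on why the exchange leaves the read-out within the scatter.

For the compounds shown here, open is how an amine, a carboxylic acid or a longer chain on this same carbon would read against compound 3, as the butyl to methoxymethyl exchange covers only one pair of chains of similar length. Also open, from the compounds shown here alone, is whether the exchange would read the same way with a different group on the rest of the molecule, or in any other assay.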